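Aryl change on the amide-type nitrogen: compound 3

The compounds below may be only part of what the source reports. "The series", "measured", "known", "first", "only" and "open" are said of these compounds alone.

Compound 1 `COc1cc2c(cc1OC)C(=O)C(CC1CCN(C(=S)Nc3ccccc3C)CC1)C2` in a functional assay on the whole organism (strain Swiss albino) with Mus musculus as the target, in the maximal electroshock model, with a stated time of 0.5 h; a higher number here means that more compound is needed for the effect, a lower number that less compound is needed: 100 mg/kg
Compound 2 `COc1cc2c(cc1OC)C(=O)C(CC1CCN(C(=S)Nc3cccc([N+](=O)[O-])c3)CC1)C2` in this assay: 300 mg/kg

For the measured compounds named here, compound 2 stands at the highest of the two numbers measured so far; its nearest neighbour is compound 1, and the single measured step is a 3.0-fold higher number from compound 1 to compound 2 (0.48 log units; beyond the scatter), in which 3-nitrophenyl replaced 2-methylphenyl on the amide-type nitrogen.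

Compound 3 `COc1cc2c(cc1OC)C(=O)C(CC1CCN(C(=S)Nc3ccccc3Cl)CC1)C2` has not yet been measured. Its difference from compound 2: 2-chlorophenyl in place of 3-nitrophenyl on an amide-type nitrogen.

Going by the values given here, the only step that bears on this is the one from compound 1, where the 3-nitrophenyl compound 2 gave a modestly higher number than the 2-methylphenyl compound 1 by a 3.0-fold higher number from compound 1 to compound 2 (0.48 log units; beyond the scatter). Compound 3 returns to a phenyl carrying a single small substituent named with the digit 2, as in compound 1, so the step is expected to run back in the opposite direction, toward a lower number, of roughly similar or somewhat smaller size: a 2.0-fold lower number from compound 2 to compound 3 (0.30 log units; within the scatter). Nothing else in the series constrains it. For compound 3 in this assay the expected value is 150 mg/kg, in the range 70 mg/kg to 300 mg/kg.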

Compound 3, minimum effective dose: 100 mg/kg
The estimate for compound 3 lay 1.5-fold (0.18 log units) above the measured number; measured number inside the range.
By their numbers in this assay, from the lowest: compounds 1 and 3 (each within the scatter of the next); then compound 2.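

In this assay, 2-chlorophenyl in place of 3-nitrophenyl on the amide-type nitrogen gives a 3.0-fold lower number from compound 2 to compound 3 (0.48 log units; beyond the scatter) and shows that the number for compound 2 is not matched by a second aryl group, as it now stands apart from both other compounds. Chloro in place of methyl on an aromatic carbon gives no change at the digits printed from compound 1 to compound 3 (within the scatter) in this assay and shows that, across these two groups, the exchange leaves the dose readout unresolved from compound 1. No measurement is available here that would account for either step.

Compound 2 differs from compounds 1 and 3 both in the substituent and in the number in its group name, so the three compounds do not show whether the higher number goes with the nitro group or with the 3-substituted pattern. A 2-nitrophenyl or a 3-chlorophenyl group would separate those two readings, while an unsubstituted phenyl group, or a 2-methoxyphenyl group, would show how much the 2-substituent itself matters on the shared core.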